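From Isobutoxy to Ethoxy in an Antiproliferative Series

A few compounds are considered here, and "the series" means these few. Any claim that something is new, unique, unknown or untested is made for them only; others in the source may bear on it.

In a functional assay on KB cells (Homo sapiens) for antiproliferative activity, read by sulforhodamine B assay, with a stated time of 3 days (on this read-out lower numbers stand for an effect already at smaller amounts and higher numbers for an effect only at larger amounts of compound), three compounds sharing one core have been measured. Compound 1 `CCCC1=C(OC)C(CCC)(CCC)C(=O)/C(=C(O)\C=C\c2ccc(I)cc2)C1=O` stands at 1.5 uM on that read-out, compound 2 `CCCC1=C(OCC(C)C)C(CCC)(CCC)C(=O)/C(=C(O)\C=C\c2ccccc2)C1=O` stands at 4.8 uM on it, and compound 3 `CCCCC1=C(OC)C(CCCC)(CCCC)C(=O)/C(=C(O)\C=C\c2ccccc2)C1=O` stands at 7 uM there. Compound 2 thus lies within the usual scatter of compound 3, while compound 1 has a lower number, beyond the scatter. These three differ in more than one place, so no single change has yet been measured on its own.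

Compound 4 `CCCC1=C(OCC)C(CCC)(CCC)C(=O)/C(=C(O)\C=C\c2ccccc2)C1=O` departs from compound 2 in one place, and methyl in place of isopropyl on a saturated chain carbon bound to an oxygen on an unsaturated carbon counts that change: methyl in place of isopropyl on a saturated chain carbon bound to an oxygen on an unsaturated carbon, or isobutoxy to ethoxy. Among the measured compounds shown here, with no measured step as a guide, the expectation in this assay is no shift beyond the scatter and no firm direction. The estimated move is a 1.0-fold higher number from compound 2 to compound 4 (0.02 log units; within the scatter) and it stays within the scatter. For compound 4 the expected value is 5 uM with an estimated range from 2.2 uM to 11 uM in this test.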

Compound 4, concentration for half-maximal effect: 6.4 uM
Estimate against measurement, compound 4: 1.3-fold (0.11 log units) below; low and high end bracket the measured number.
By their numbers in this assay, from the lowest: compound 1; then compounds 2, 4 and 3 (each within the scatter of the next).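

In this assay, among the compounds shown here, the exchange of isobutoxy for ethoxy gives a 1.3-fold higher number from compound 2 to compound 4 (0.12 log units; within the scatter), the first change in this set to be measured on its own. On a saturated chain carbon bound to an oxygen on an unsaturated carbon, methyl in place of isopropyl therefore leaves the read-out within the usual scatter, with the rest of compound 2 unchanged. No available evidence bears on this result.

As far as these compounds go, whether a longer chain such as hexyl, or a chain ending in an amine or a carboxylic acid, would also stay within the scatter at this place remains open. From the compounds shown here alone, it also remains open whether the same exchange would read alike in a compound carrying the iodine of compound 1.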